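The source may report more compounds than this note shows. Statements on the series, on what has been measured and on what is new or still open speak of the compounds shown alone.

Of the compounds shown here, three have numbers so far in a functional assay on DU-145 cells (Homo sapiens) for inhibition, read by trypan blue exclusion, with a stated time of 96 h; on this read-out higher numbers stand for weaker inhibition of growth and lower numbers for stronger inhibition of growth. Compound 1 (`Cc1ccc(/C=C(\C(=O)c2ccc([N+](=O)[O-])cc2)S(=O)(=O)Cc2ccc(Cl)cc2)s1`) gives 25000 nM. Compound 2 (`CN(C)c1ccc(/C=C(/SCc2ccc(Br)cc2)C(=O)c2ccc(C(=O)O)cc2)cc1`) gives 50000 nM, and this lies within the usual scatter of the value for compound 1, so the two cannot be told apart. Compound 3 (`O=C(/C(=C\c1ccc(F)cc1F)Sc1ccc(Br)cc1)c1ccc(Br)cc1`) gives 1000 nM, a number lower than that of compound 1 by well beyond the scatter, which means stronger inhibition of growth. Compound 1 therefore sits at the high-number end of this small set, level with compound 2.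

Compound 4 (`COc1ccccc1/C=C(\C(=O)c1ccc([N+](=O)[O-])cc1)S(=O)(=O)Cc1ccc(Cl)cc1`) has not been measured yet. It keeps the core of compound 1 but carries 2-methoxyphenyl in place of 5-methylthiophen-2-yl on a double-bonded chain carbon bound to a double-bonded chain carbon. Among the measured compounds shown here, compounds 2 and 3 differ from compound 1 in several places, so no measured pair shows what this swap does on its own. The best guide is compound 1 itself, at 25000 nM, and no step beyond the scatter is expected in this assay, in either direction. The expected change is a 1.3-fold lower number from compound 1 to compound 4 (0.10 log units; within the scatter). In this assay the estimate for compound 4 is 20000 nM, with an expected range of 6000 nM to 60000 nM.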

Compound 4, concentration for 50% growth inhibition: 10000 nM
The estimate for compound 4 lay 2.0-fold (0.30 log units) above the measured number; the range from low to high includes it.
By their numbers in this assay, from the lowest: compound 3; then compound 4; then compounds 1 and 2 (each within the scatter of the next).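

Among the compounds shown here, this is the first pair of compounds that differ in one place only, so the group on this double-bonded chain carbon can now be judged on its own. In this assay, putting 2-methoxyphenyl in place of 5-methylthiophen-2-yl gives a 2.5-fold lower number from compound 1 to compound 4 (0.40 log units; beyond the scatter), a modest step beyond the usual scatter, which shows that growth inhibition responds to the group at this position, with the six-membered carbon ring and its methoxy group giving the stronger inhibition of the two. No measurement at hand explains this step, so the reason for it remains unknown.

The swap replaces a five-membered ring containing sulfur with a six-membered carbon ring and also exchanges a methyl group for a methoxy group, so this single pair cannot show which of these differences matters. Going by these compounds, compounds carrying an unsubstituted phenyl, a 5-methylfuran-2-yl or a 2-hydroxyphenyl group at this position would be needed to separate the effect of the ring from that of its substituent, and whether an amine or a carboxylic acid would be tolerated there also remains open.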